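The source may hold more compounds than are shown below. What is called first, only, known or untested is meant among the compounds shown, and "the series" means these compounds.

Measured compounds:
compound 1 `CCCCCc1cccc(NC(=O)NCCCCl)c1`: 26000 nM
compound 2 `O=C(CCl)Nc1ccc(I)cc1`: 6200 nM
compound 3 `CC(C)(C)c1ccc(NC(=O)CCl)cc1`: 5400 nM

All three have been run in a functional assay on MCF7 cells (Homo sapiens) for antiproliferative activity, with a stated time of 48 h; on this read-out lower numbers stand for stronger inhibition and higher numbers for weaker inhibition. Compound 3 has the lowest number of the three; its gap to compound 2 is within the scatter, while its gap to compound 1 is beyond it. For the measured compounds named here, the one step between compounds that differ in a single place is a 1.1-fold lower number from compound 2 to compound 3 (0.06 log units; within the scatter), a change on the aromatic ring.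

Compound 4 `C=CC(=O)Nc1ccc(C(C)(C)C)cc1` has not yet been measured. It differs from compound 3 by vinyl in place of chloromethyl on a carbonyl carbon. Going by the values given here, no measured step concerns this part of the molecule: the only measured step lies on the aromatic ring, not on the carbonyl carbon, so it gives no guide to the size or direction of the present change. With nothing to go on but the number for compound 3 and the absence of any precedent, the expected step is a 1.1-fold higher number from compound 3 to compound 4 (0.05 log units; within the scatter), that is none beyond the scatter, and the range is set wide to reflect the missing precedent. Compound 4 is therefore expected to give 6000 nM in this assay, within a range from 2000 nM to 18000 nM.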

Compound 4, half-maximal inhibitory concentration: 29000 nM
Beside the measured number, compound 4's estimate is 4.8-fold (0.68 log units) below it; the measured number lies above the stated range.
By their numbers in this assay, from the lowest: compounds 3 and 2 (each within the scatter of the next); then compounds 1 and 4 (each within the scatter of the next).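

In this assay, for the compounds shown here, the carbonyl carbon proves to be a position where a change registers: a 5.4-fold higher number from compound 3 to compound 4 (0.73 log units; beyond the scatter) is beyond the scatter, whereas the only earlier step, on the aromatic ring, stayed within it (a 1.1-fold lower number from compound 2 to compound 3 (0.06 log units; within the scatter)). With tert-butyl on the aromatic ring held the same, chloromethyl on this carbonyl carbon goes with the lower number and vinyl with the higher, even though the two groups have the same count of heavy atoms and neither carries a hydrogen-bond donor or acceptor, so those counts do not separate them. No supporting data bear on why the number rises, and the change stands as an observation on this single pair.

The compounds shown do not tell whether the higher number goes with the loss of the chlorine or with the arrival of the double bond, nor whether the step would hold with iodo in place of tert-butyl on the aromatic ring. An ethyl or a bromomethyl group on the same carbonyl carbon would help to separate these readings.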